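A few compounds are considered here, and "the series" means these few. Any claim that something is new, unique, unknown or untested is made for them only; others in the source may bear on it.

Of the compounds shown here, two of the shared core have been measured in a functional assay on K562 cells (Homo sapiens) for inhibition, read by MTT assay, with a stated time of 24 h; on this read-out higher numbers stand for weaker inhibition and lower numbers for stronger inhibition. Compound 1 `O=C(Cn1c(=O)c(/C=C\c2ccncc2)nc2ccccc21)Nc1ccccc1` gives 55500 nM. Compound 2 `O=C(Cn1c(=O)c(/C=C\c2ccncc2)nc2ccccc21)Nc1ccc(Cl)cc1` returns only a limit of the assay, > 50400 nM, so where compound 2 stands on the numbers shown is open beyond that limit. For the measured compounds named here, the single measured step, a step that the limit leaves unreadable from compound 1 to compound 2, cannot be sized because of the limit of > 50400 nM in this assay, at which 1 of the 2 values shown sits. Compound 3 `COc1ccc(NC(=O)Cn2c(=O)c(/C=C\c3ccncc3)nc3ccccc32)cc1OC` differs from compound 2 by 3,4-dimethoxyphenyl in place of 4-chlorophenyl on an amide-type nitrogen. No readable step concerns a change at this amide-type nitrogen; the only shown step touches the same position but its size is hidden. Both measured values sit at the weak end of this assay, and nothing shown points to a move in either direction. For compound 3 a step that the limit leaves unreadable from compound 2 to compound 3 is expected, meaning nothing beyond the scatter. The estimate for compound 3 is 60000 nM, with a range from 20000 nM to 180000 nM, and a reading that is again only a limit is thought likely.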

Compound 3, half-maximal inhibitory concentration: 55200 nM
Compound 3: middle estimate off by 1.1-fold (0.04 log units), on the high side; measured number inside the range.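

For the compounds shown here, on the amide-type nitrogen, 3,4-dimethoxyphenyl in place of phenyl gives the first readable step at this position in this assay: a 1.0-fold lower number from compound 1 to compound 3 (0.00 log units; within the scatter). Compound 1 and compound 3 therefore cannot be ordered, and this exchange of phenyl for 3,4-dimethoxyphenyl shows no readable effect on the number. Compound 2 gives only a limit, so its steps to compound 1 and compound 3 cannot be read: the limit of > 50400 nM in this assay, at which 1 of the 3 values shown sits.

Whether any group on this nitrogen can move the number beyond the scatter stays open, since phenyl, 4-chlorophenyl and 3,4-dimethoxyphenyl are the only groups shown there. Also open, from the compounds shown here alone, is how a carboxylic acid or an amine on that phenyl ring, or a longer chain in its place, would read, as is any change elsewhere on the shared core.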